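The compounds below may be only part of what the source reports. "The series", "measured", "known", "first", "only" and "open" are said of these compounds alone.

Of the compounds shown here, three have been measured in a physicochemical assay for solubility, read by HPLC; on this read-out lower numbers stand for lower solubility and higher numbers for higher solubility. Compound 1, `O=[N+]([O-])c1nccn1CS(=O)(=O)NCCN1CCCC1`, gives 16100000 nM. Compound 2, `O=[N+]([O-])c1nccn1CS(=O)(=O)NN1CCOCC1`, gives 1080000 nM. Compound 3, `COCCCNS(=O)(=O)CCn1c([N+](=O)[O-])cnc1C`, gives 17000000 nM. Among these three numbers compound 3 stands highest: its nearest neighbour is compound 1, whose number is within the scatter of compound 3, so no order between the two can be read, while compound 2 lies far below both, beyond the scatter.

Compound 4, `Cc1ncc([N+](=O)[O-])n1CCS(=O)(=O)NCCCN(C)C`, has not yet been measured in this assay. It differs from compound 3 in one place: dimethylamino in place of methoxy on a saturated chain carbon, three bonds along the chain from a sulfonamide nitrogen. Within the data shown here, no step between measured compounds matches this change, so the expectation rests on the standing of compound 3 and on compound 1, which also carries a basic amine on the chain and gives a number within the scatter of compound 3. The step from compound 3 to compound 4 is therefore expected to be small, a 1.2-fold higher number from compound 3 to compound 4 (0.07 log units; within the scatter), and not beyond the scatter in either direction. Compound 4 is expected to give 20000000 nM, with a range from 8000000 nM to 50000000 nM.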

Compound 4, solubility: > 53800000 nM
Compound 4 gave a limit, no number (the forecaster's own chance of this, stated with the estimate: 10%); at least 2.6-fold (0.42 log units) between middle value and limit.
By their numbers in this assay, from the lowest: compound 2; then compounds 1 and 3 (each within the scatter of the next). At a limit, above all of these: compound 4.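

In this assay, dimethylamino in place of methoxy on a saturated chain carbon, three bonds along the chain from a sulfonamide nitrogen, gives an at least 3.1-fold higher number from compound 3 to compound 4 (0.50 log units; beyond the scatter). This is the only step shown between compounds that differ in one place, so it is the first sign that this part of the chain can move the read-out beyond the scatter. Its full size cannot be read, because the value of compound 4 is a limit and not a number: the limit of > 53800000 nM in this assay, at which 1 of the 4 values shown sits.

The compounds shown leave open whether the same change holds with the shorter 2-(dimethylamino)ethyl or with a longer chain. They also leave open what a primary amine or a carboxylic acid would give in this place.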